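The source may hold more compounds than are shown below. What is called first, only, known or untested is meant among the compounds shown, and "the series" means these compounds.

Compound 1 `CCc1cc(C(C)=O)c(O)cc1OCCCCCCC#N`: 103%
Compound 2 `CCc1cc(C(C)=O)c(O)cc1OCCCCC(C)(C)C#N`: 79%

In an assay on isolated protein for inhibition of leukotriene B4 receptor 1 (Homo sapiens), tested at 10 uM (on this read-out higher numbers stand for more inhibition at the one concentration tested (going by the name of the read-out) and lower numbers for less inhibition), compound 2 stands lowest of the two numbers, with compound 1 the nearer one, as the step of a number 24 percentage points lower from compound 1 to compound 2 (beyond the scatter) shows. Compound 3 `CCc1cc(C(C)=O)c(O)cc1OCCCCCCC(C)(C)C#N` differs from compound 2 by 3-cyano-3-methylbutyl in place of 1-cyano-1-methylethyl on a saturated chain carbon, four bonds along the chain from an oxygen on an aromatic ring. Among the measured compounds shown here, only the step from compound 1 to compound 2 bears on this change, and it was modest yet beyond the scatter. Compound 3 carries the nitrile on a chain of a length closer to that of compound 1, so the expected step of a number 13 percentage points higher from compound 2 to compound 3 (beyond the scatter) is a rise, partly recovering that loss. For compound 3 an inhibition of 92% is estimated, within 75% to 105%.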

Compound 3, a percentage reported as inhibition, at one concentration (the size of the read-out at that concentration, not a potency): 65%
Compound 3: the middle estimate sits 27 percentage points above what was measured, outside the stated range (below it).
By their numbers in this assay, from the lowest: compound 3; then compound 2; then compound 1.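

In this assay, 3-cyano-3-methylbutyl in place of 1-cyano-1-methylethyl does not win back the earlier loss, giving a number 14 percentage points lower from compound 2 to compound 3 (beyond the scatter) instead. The larger cost appears when 1-cyano-1-methylethyl replaces cyano at the position six bonds along the chain, with a number 38 percentage points lower from compound 1 to compound 3 (beyond the scatter), so a longer chain carrying this branched end does not restore the number. Nothing measured here accounts for this fall.

The compounds shown do not separate the effect of chain length from that of the branching at the nitrile carbon. As far as these compounds go, how a longer unbranched chain ending in a nitrile, or a carboxylic acid in place of the nitrile, would read remains open.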